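The source may hold more compounds than are shown below. What is called first, only, known or untested is meant among the compounds shown, and "the series" means these compounds.

Measured so far:
compound 1 `Cc1ccc(C2C(C#N)=C(N)N(c3ccc(S(N)(=O)=O)cc3)C3=C2C(=O)CCC3)cc1`: 50%
compound 2 `COc1ccc(C2C(C#N)=C(N)N(c3ccc(S(N)(=O)=O)cc3)C3=C2C(=O)CCC3)c2ccccc12`: 30%

In a functional assay on Ehrlich cells (Mus musculus) for antiproliferative activity, read by trypan blue exclusion, with a stated time of 2 h, tested at 50 ug/mL (a lower number here means a weaker effect, a higher number a stronger effect of the compound at the concentration tested), compound 1 gives 50% and stands highest of the two numbers; compound 2 gives 30%, the step of a number 20 percentage points lower from compound 1 to compound 2 (beyond the scatter) lying beyond the scatter. Compound 3 `N#CC1=C(N)N(c2ccc(S(N)(=O)=O)cc2)C2=C(C(=O)CCC2)C1c1ccco1` is not yet measured. It differs from compound 1 in one place: furan-2-yl in place of 4-methylphenyl on a saturated ring carbon. Within the data shown here, the only measured step that bears on this change is a number 20 percentage points lower from compound 1 to compound 2 (beyond the scatter), where another group took the place of 4-methylphenyl on a saturated ring carbon; that step did not involve furan-2-yl, so it fixes no direction for the present change and gives only a sense of scale. Among the measured compounds shown here, since the one exchange at that carbon lowered the number modestly, a small loss or no change beyond the scatter is expected here. For compound 3 the estimate is 40%, range 20% to 60%. This expected result for compound 3 amounts to a step of a number 10 percentage points lower from compound 1 to compound 3 (within the scatter).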

Compound 3, a percentage reported as activity, at one concentration (the size of the read-out at that concentration, not a potency): 5%
Beside the measured number, compound 3's estimate is 35 percentage points above it, and the stated range ends above it.
By their numbers in this assay, from the lowest: compound 3; then compound 2; then compound 1.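

In this assay, the group on this saturated ring carbon can remove most of the read-out, not just part of it: furan-2-yl in place of 4-methylphenyl gives a number 45 percentage points lower from compound 1 to compound 3 (beyond the scatter) and is the larger of the two changes now seen at this position. Furan-2-yl in place of 4-methoxynaphthalen-1-yl gives a number 25 percentage points lower from compound 2 to compound 3 (beyond the scatter) so compound 3 stands lowest of the three, with both of its steps beyond the scatter, and the five-membered aromatic ring with one oxygen falls below both groups tested earlier. No measurement at hand accounts for this drop.

As far as these compounds go, whether the loss belongs to the ring oxygen or to the smaller ring remains open. Thiophen-2-yl, phenyl or cyclohexyl at this carbon would help separate the two, and a single tested concentration leaves potency undefined.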